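This account rests on a few compounds, and the source may have more. Where it says the series, first, only, none or still open, it means among the compounds named here.

Three compounds have been measured in an ADME assay on cells (Hepatocyte, Mus musculus) for metabolic stability, read by LC-MS, with a stated time of 10 min, tested at 1 uM; on this read-out lower numbers stand for slow clearance and higher numbers for fast clearance:

Compound 1 `O=C(NCc1ccc(S(=O)(=O)c2cccc(C(F)(F)F)c2)cc1)c1cc2cnccc2[nH]1`: 60 mL/min/kg
Compound 2 `O=C(NCc1ccc(S(=O)(=O)c2cc(F)cc(F)c2)cc1)c1cnc2nccn2c1`: 74 mL/min/kg
Compound 3 `O=C(NCc1ccc(S(=O)(=O)c2cccc(C(F)(F)F)c2)cc1)c1cc2ccncc2o1`: 25 mL/min/kg

Compound 3 stands lowest of the three at 25 mL/min/kg, and both other numbers lie above it by more than the scatter. Compound 4 `O=C(NCc1ccc(S(=O)(=O)c2cccc(C(F)(F)F)c2)cc1)c1cc2ccncc2s1` has not yet been measured in this assay. It differs from compound 3 in one place: a group of 9 heavy atoms (7 carbon, 1 nitrogen, 1 sulfur; one five-membered aromatic ring with 1 hetero atom, one six-membered aromatic ring with 1 hetero atom) in place of a group of 9 heavy atoms (7 carbon, 1 nitrogen, 1 oxygen; one five-membered aromatic ring with 1 hetero atom, one six-membered aromatic ring with 1 hetero atom), on a carbonyl carbon.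

Within the data shown here, only one measured step bears on this change. It sits at the same place on the carbonyl carbon and is a swap of one hetero atom in the same kind of group: a 2.4-fold lower number from compound 1 to compound 3 (0.38 log units; beyond the scatter). That modest step shows that such a swap can move the clearance beyond the scatter. Among the measured compounds shown here, compound 2 differs from compound 3 in more than one place and offers no comparable step. For the measured compounds named here, no measured compound carries the entering group, so there is no direct precedent for it.

A step no larger than the measured one is therefore expected, probably within the scatter, with a slight lean towards compound 1 at 60 mL/min/kg. The expected change is a 1.4-fold higher number from compound 3 to compound 4 (0.13 log units; within the scatter). The estimate for compound 4 is 34 mL/min/kg, with an expected range from 16 mL/min/kg to 70 mL/min/kg.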

Compound 4, clearance: 73 mL/min/kg
For compound 4 the middle estimate is 2.1-fold (0.33 log units) below the measured one; the whole stated range lies below it.
By their numbers in this assay, from the lowest: compound 3; then compounds 1, 4 and 2 (each within the scatter of the next).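

In this assay, exchanging the oxygen of the group on the carbonyl carbon for sulfur, with the counts of heavy atoms, hydrogen-bond donors and hydrogen-bond acceptors unchanged, gives a 2.9-fold higher number from compound 3 to compound 4 (0.47 log units; beyond the scatter), so this one hetero atom swap at this place moves the clearance beyond the scatter. The other step, a 1.2-fold higher number from compound 1 to compound 4 (0.09 log units; within the scatter), lies within the scatter, which leaves the sulfur group and the nitrogen-containing group of compound 1 indistinguishable here, while among these three compounds only the oxygen group stands apart, with a lower number than either. The compounds shown offer no independent measurement that would explain why the oxygen and sulfur groups part in this way.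

Going by these compounds, whether the oxygen group would keep its low number with a different substituent on the aryl sulfone, such as the two fluorines of compound 2 in place of trifluoromethyl, remains open, since compound 2 differs from these compounds in more than one place. Also open, on these data alone, is how an added amine or methoxy group on the oxygen-containing group would move the clearance.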